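The compounds below may be only part of what the source reports. "The series", "measured", "known", "first", "only" and "open" are said of these compounds alone.

Values in a functional assay on HeLa cells (Homo sapiens) for antiproliferative activity, read by MTT assay, with a stated time of 72 h; on this read-out higher numbers stand for weaker inhibition and lower numbers for stronger inhibition:
- compound 1 `C/C=C/C(=O)Nc1cccc(Oc2nc(Nc3cccc(OC)c3)nc3c2CSCC3)c1`: 13800 nM
- compound 2 `CC/C=C/C(=O)Nc1cccc(Oc2nc(Nc3cccc(OC)c3)nc3c2CSCC3)c1`: 27200 nM
- compound 3 `CCC/C=C/C(=O)Nc1cccc(Oc2nc(Nc3cccc(OC)c3)nc3c2CSCC3)c1`: 33800 nM

In this assay, compound 3 is not separated from its nearest neighbour, as shown by a 1.2-fold higher number from compound 2 to compound 3 (0.09 log units; within the scatter). Against the furthest value, the series shows a 2.4-fold higher number from compound 1 to compound 3 (0.39 log units; beyond the scatter), a modest step.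

The next structure is compound 4 `COc1cccc(Nc2nc3c(c(Oc4cccc(NC(=O)/C=C/C(C)C)c4)n2)CSCC3)c1`, with isopropyl in place of propyl on a double-bonded chain carbon bound to a double-bonded chain carbon. Among the measured compounds shown here, no measured compound carries a branched chain, so no measured step matches this change directly.

The nearest guides are chain changes at the same end of the molecule. Adding methyl to the chain gave a 2.0-fold higher number from compound 1 to compound 2 (0.29 log units; within the scatter), and adding a further methyl gave a 1.2-fold higher number from compound 2 to compound 3 (0.09 log units; within the scatter). Both are small, and the second comes with no real change in this assay. Rearranging the same carbons is therefore expected to give no step beyond the scatter, and the expected step is a 1.1-fold lower number from compound 3 to compound 4 (0.02 log units; within the scatter).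

For compound 4 the estimated value is 32000 nM, with an expected range of 16000 nM to 60000 nM.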

Compound 4, half-maximal inhibitory concentration: > 50000 nM
Compound 4 ended at the assay's limit (the forecaster's own chance of this, stated with the estimate: 15%); middle value at least 1.5-fold (0.19 log units) away from the limit.
By their numbers in this assay, from the lowest: compounds 1, 2 and 3 (each within the scatter of the next, the first and the last beyond it). At a limit, above all of these: compound 4.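

In this assay compound 4 is a limit of the assay and not a number: the limit of > 50000 nM in this assay, at which 1 of the 4 values shown sits. With the same atoms joined differently, isopropyl in place of propyl gives an at least 1.4-fold higher number from compound 3 to compound 4 (0.17 log units; that floor lies within the scatter), and the comparison with the ethyl-ended chain gives an at least 1.8-fold higher number from compound 2 to compound 4 (0.26 log units; that floor lies within the scatter); both floors lie within the scatter, so the true size of these steps cannot be read. Among the compounds shown here, the one step that clears the scatter is an at least 3.6-fold higher number from compound 1 to compound 4 (0.55 log units; beyond the scatter), so branching at this place brings no gain and leaves the isopropyl compound clearly separated from the methyl-ended compound 1.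

As far as these compounds go, how far compound 4 lies past the limit remains open. Also open, from the compounds shown here alone, is whether an amine or a carboxylic acid at the chain end, or plain hydrogen in place of the methyl of compound 1, would lower the number.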